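Pyridine acids on a fused bicyclic core: amine for thiophene

The source may hold more compounds than are shown below. What is called first, only, known or untested is meant among the compounds shown, and "the series" means these compounds.

Measured so far:
compound 1 `O=C(O)c1cccc(Cc2c(-c3ccccc3)nn3cc(F)ccc23)n1` — 380 nM
compound 2 `O=C(O)c1cccc(Cc2c(-c3ccsc3)nn3cc(Cl)ccc23)n1` — 110 nM

Two compounds of the series carry a number in a functional assay on cells for antagonist activity at prostaglandin E2 receptor EP1 subtype (Rattus norvegicus), read by fluorescence and calcium flux, with a stated time of 60 s; a lower number here means a stronger inhibitor, a higher number a weaker inhibitor. Compound 1 `O=C(O)c1cccc(Cc2c(-c3ccccc3)nn3cc(F)ccc23)n1` gives 380 nM in this assay. Compound 2 `O=C(O)c1cccc(Cc2c(-c3ccsc3)nn3cc(Cl)ccc23)n1` gives 110 nM and so stands at the lower of the two numbers; the gap to compound 1 lies beyond the scatter. Compound 1 and compound 2 differ in two places at once, so neither change can be read on its own.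

Compound 3 `O=C(O)c1cccc(Cc2c(N3CCCC3)nn3cc(Cl)ccc23)n1` is not yet measured. It differs from compound 2 in one place: pyrrolidin-1-yl in place of thiophen-3-yl on an aromatic carbon. Within the data shown here, no measured pair shows the effect of swapping an aromatic five-membered ring for a saturated one at this position, so the direction is open. A saturated amine in place of the thiophen-3-yl is a larger departure than the phenyl-to-thiophene difference between compound 1 and compound 2, and the step from compound 2 to compound 3 is expected to be a 2.7-fold higher number from compound 2 to compound 3 (0.44 log units; beyond the scatter), toward a weaker inhibitor, with wide uncertainty. Compound 3 is estimated at 300 nM in this assay, within 80 nM to 1200 nM.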

Compound 3, half-maximal inhibitory concentration: 1800 nM
Compound 3: middle estimate off by 6.0-fold (0.78 log units), on the low side; the measured number lies above the stated range.
By their numbers in this assay, from the lowest: compound 2; then compound 1; then compound 3.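

In this assay, among these compounds, the change from thiophen-3-yl to pyrrolidin-1-yl gives a 16-fold higher number from compound 2 to compound 3 (1.21 log units; beyond the scatter), the first single-place reading at this aromatic carbon and a large step. The position therefore does not tolerate every five-membered ring, even though the two groups match in the counts computed here: 5 heavy atoms, one ring with 1 hetero atom, 0 hydrogen-bond donors, 1 hydrogen-bond acceptor and no net charge. They differ in that the ring entering is non-aromatic, joins through its nitrogen and carries no sulfur, but nothing available here shows why the number rises or which of these differences matters.

Among the compounds shown here, the single step ties those differences together, so a cyclopentyl group, joined through carbon, and a pyrrol-1-yl group, aromatic and joined through nitrogen, would be needed on the chlorine-bearing core of compound 2 to pull them apart. On these data alone, it also remains open how a phenyl group compares with thiophen-3-yl at this position, and how fluorine compares with chlorine on the core, as compound 1 and compound 2 differ in both places at once.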